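A few compounds are considered here, and "the series" means these few. Any claim that something is new, unique, unknown or untested is made for them only; others in the source may bear on it.

Three compounds have been measured in a functional assay on MDA-MB-231 cells (Homo sapiens) for cytotoxicity, read by sulforhodamine B assay, with a stated time of 72 h; a lower number here means a stronger inhibitor of growth, a higher number a weaker inhibitor of growth:

Compound 1 `O=C(Nc1ccccc1C(F)(F)F)C1CCc2ccccc2N1C(=O)c1ccccc1` gives 5290 nM.
Compound 2 `COc1ccc(NC(=O)C2CCc3ccccc3N2)cc1` gives 51400 nM.
Compound 3 `O=C(Nc1cc(C(F)(F)F)cc(C(F)(F)F)c1)C1CCc2ccccc2N1C(=O)c1ccc(Cl)cc1` gives 2000 nM.

Among these three, compound 3 stands lowest in this assay. Its nearest neighbour is compound 1, whose number is higher by an amount beyond the usual scatter, and compound 2 lies far above both. No pair of these compounds differs in only one place, so no single change can be read off from the measured set.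

Compound 4 `O=C(Nc1cc(C(F)(F)F)cc(C(F)(F)F)c1)C1CCc2ccccc2N1C(=O)c1ccccc1Cl` has not yet been measured. It keeps the same atoms as compound 3, joined differently: 2-chlorophenyl in place of 4-chlorophenyl on a carbonyl carbon. Going by the values given here, since no comparable step is available among the measured compounds, the size of this step can only be expected, not read. The expectation is a small step from compound 3 to compound 4, toward a somewhat higher number, quite possibly within the scatter, estimated as a 1.5-fold higher number from compound 3 to compound 4 (0.18 log units; within the scatter). Compound 4 is thus estimated at 3000 nM, with a range from 1200 nM to 7500 nM.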

Compound 4, concentration for 50% growth inhibition: 5250 nM
Compound 4: middle estimate off by 1.8-fold (0.24 log units), on the low side; measured number inside the range.
By their numbers in this assay, from the lowest: compound 3; then compounds 4 and 1 (each within the scatter of the next); then compound 2.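

In this assay, the exchange of 4-chlorophenyl for 2-chlorophenyl on the carbonyl carbon gives a 2.6-fold higher number from compound 3 to compound 4 (0.42 log units; beyond the scatter) even though the atoms stay the same. This first single-place comparison shows that the number at this position depends on how the chlorophenyl group is joined, not only on which atoms are present. Nothing available explains the size or direction of this step.

The compounds shown leave open how a bromine or a methyl group in place of the chlorine would read in either arrangement. They also do not show whether the step would keep its size with a carboxylic acid on the other aromatic ring in place of the two trifluoromethyl groups of compound 3 and compound 4.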